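Estimating plasma binding after enlarging one ring substituent

This account rests on a few compounds, and the source may have more. Where it says the series, first, only, none or still open, it means among the compounds named here.

- compound 1 `O=C(O)c1cn(Cc2ccc(-n3cccn3)cc2)c2cccc(F)c2c1=O` gives 89.8%
- compound 2 `Cc1ccn(-c2ccc(Cn3cc(C(=O)O)c(=O)c4c(F)cccc43)cc2)n1` gives 92.3%
- compound 3 `O=C(O)c1cn(Cc2ccc(-n3cnc4ccccc43)cc2)c2cccc(F)c2c1=O` gives 96.1%

In an ADME assay on a cell-free system (plasma, Homo sapiens) for protein binding, with Plasma (Rattus norvegicus) as the target, compound 2 gives 92.3% and stays close to both other compounds. Both a 1.3-fold lower unbound fraction from compound 1 to compound 2 (0.12 log units; within the scatter) and a 2.0-fold lower unbound fraction from compound 2 to compound 3 (0.30 log units; within the scatter) are small steps.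

Compound 4 `O=C(O)c1cn(Cc2ccc(-n3ccc4cccnc43)cc2)c2cccc(F)c2c1=O` differs from compound 2 in one group only, on an aromatic carbon of a six-membered aromatic ring of carbon only. The change is a group of 9 heavy atoms (7 carbon, 2 nitrogen; one five-membered aromatic ring with 1 hetero atom, one six-membered aromatic ring with 1 hetero atom) in place of a group of 6 heavy atoms (4 carbon, 2 nitrogen; one five-membered aromatic ring with 2 hetero atoms), on an aromatic carbon and the rest of the structure stays the same.

Going by the values given here, no measured compound carries the entering group. The nearest guide is compound 3, with 1H-benzimidazol-1-yl in the same place. Both a 2.0-fold lower unbound fraction from compound 2 to compound 3 (0.30 log units; within the scatter) and a 2.6-fold lower unbound fraction from compound 1 to compound 3 (0.42 log units; beyond the scatter) point towards less free compound. The methyl swap, a 1.3-fold lower unbound fraction from compound 1 to compound 2 (0.12 log units; within the scatter) says little about this change.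

Going by compound 3 at 96.1% a step in the same direction is expected, similar in size or somewhat smaller. The expected step is a 1.7-fold lower unbound fraction from compound 2 to compound 4 (0.23 log units; within the scatter) and it rests on this single guide. For compound 4 the estimated value is 95.5% with an expected range from 92.5% to 97.5% in this read-out.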

Compound 4, plasma protein binding: 98.8%
The estimate for compound 4 lay 3.8-fold (0.57 log units) (unbound fraction) above the measured number; the whole stated range lies below it.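

In this assay, this position responds strongly to the larger two-ring group: a 6.4-fold lower unbound fraction from compound 2 to compound 4 (0.81 log units; beyond the scatter) and an 8.5-fold lower unbound fraction from compound 1 to compound 4 (0.93 log units; beyond the scatter) are both steps beyond the scatter. The new result also shows that counting atoms is not enough, since the groups in compound 3 and compound 4 have the same 9 heavy atoms, 7 carbon and 2 nitrogen, yet a 3.3-fold lower unbound fraction from compound 3 to compound 4 (0.51 log units; beyond the scatter) still lies beyond the scatter. What differs between those two groups is how the hetero atoms are shared out, with one in each ring of compound 4 and both in the five-membered ring of compound 3.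

Why this arrangement leaves less compound free remains unexplained, as nothing available bears on the cause. Going by these compounds, it is also open how the same position would respond if the entering group carried an amine or a morpholine ring.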